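The source may report more compounds than this note shows. Statements on the series, on what has been measured and on what is new or still open speak of the compounds shown alone.

Measured so far in a functional assay on HEK293 cells for antagonist activity at transient receptor potential cation channel subfamily V member 1 (Homo sapiens), read by FLIPR; on this read-out lower numbers stand for stronger inhibition and higher numbers for weaker inhibition:
compound 1 `O=C(Nc1cccc2cnccc12)NC1CCc2cc(F)ccc2C1Cc1ccccc1` gives 12 nM
compound 2 `O=C(Nc1cccc2cnccc12)NC1CCc2cc(F)ccc2C1Cc1ccoc1` gives 83 nM

Compound 2 stands at the higher of the two numbers in this assay; compound 1 lies lower, separated by the step of a 6.9-fold higher number from compound 1 to compound 2 (0.84 log units; beyond the scatter), which is beyond the scatter. The next compound to be read in this assay, compound 3 `O=C(Nc1cccc2cnccc12)NC1CCc2cc(F)ccc2C1CC1CC1`, carries the change (cyclopropyl in place of furan-3-yl on a saturated chain carbon bound to a saturated ring carbon).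

Among the measured compounds shown here, only one measured step bears on this position: the exchange of phenyl for furan-3-yl, a 6.9-fold higher number from compound 1 to compound 2 (0.84 log units; beyond the scatter), a modest loss. It shows that the group on this saturated chain carbon moves the number beyond the scatter, but no measured compound carries a non-aromatic ring there, so the direction for cyclopropyl is not shown by the data. For the measured compounds named here, with no closer precedent, the number for compound 3 is taken as near that of compound 2, with a range wide enough to cover a further modest loss or a partial return toward compound 1.

Compound 3 is therefore expected at about 110 nM in this assay, between 30 nM and 450 nM. This estimate amounts to an expected step of a 1.3-fold higher number from compound 2 to compound 3 (0.12 log units; within the scatter), within the scatter.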

Compound 3, half-maximal inhibitory concentration: 350 nM
Estimate against measurement, compound 3: 3.2-fold (0.50 log units) below; the range from low to high includes it.
By their numbers in this assay, from the lowest: compound 1; then compound 2; then compound 3.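

In this assay the only non-aromatic ring shown on this saturated chain carbon brings a 4.2-fold higher number from compound 2 to compound 3 (0.62 log units; beyond the scatter) and extends the loss seen on leaving phenyl instead of reversing it, while the full exchange comes to a 29-fold higher number from compound 1 to compound 3 (1.46 log units; beyond the scatter) and is large. The two aromatic rings of compound 1 and compound 2 therefore hold lower numbers at this position than the cyclopropyl of compound 3, and with the rest of the structure unchanged, this one group spans a large part of the range seen so far. Nothing at hand accounts for this order of the three groups.

Phenyl, furan-3-yl and cyclopropyl differ at once in ring size and in aromatic character, so the compounds shown cannot separate the two, and a cyclohexyl ring on the same carbon would bear directly on that question. Also open, going by these compounds, is whether a ring is needed here at all, which a plain longer chain or an amine on this saturated chain carbon would address.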